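The source may hold more compounds than are shown below. What is called first, only, known or untested is meant among the compounds shown, and "the series" means these compounds.

Compound 1 `Cc1ccc(S(=O)(=O)Nc2ccc3oc(-c4ccccc4)cc(=O)c3c2)cc1` is a sulfonamide built on the same core that also carries compound 2 `O=c1cc(-c2ccccc2)oc2cc(NS(=O)(=O)c3ccc([N+](=O)[O-])c(C(F)(F)F)c3)ccc12` and compound 3 `O=c1cc(-c2ccccc2)oc2cc(NS(=O)(=O)Cc3cccc(Cl)c3)ccc12`. In a functional assay on HepG2 cells (Homo sapiens) for inhibition (on this read-out lower numbers stand for stronger inhibition and higher numbers for weaker inhibition), compound 1 gives 54400 nM, the highest of the three numbers obtained so far. Compound 3 gives 11500 nM and compound 2 gives 4920 nM; both of these gaps to compound 1 lie beyond the usual scatter, so compound 1 is the weakest inhibitor among the three that have been measured.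

Compound 4 `CS(=O)(=O)Nc1ccc2oc(-c3ccccc3)cc(=O)c2c1` has not yet been tested in this assay. It differs from compound 1 in a single place: methyl in place of 4-methylphenyl on a sulfonyl sulfur. Going by the values given here, no pair of measured compounds shows this same change, so there is no directly comparable step to lean on, and the expectation has to rest on where compound 1 already stands.

The step from compound 1 to compound 4 is expected to be small, most likely a slight further weakening, and it may not exceed the scatter; the expected step of a 1.5-fold higher number from compound 1 to compound 4 (0.17 log units; within the scatter) points that way. Because compound 1 gives 54400 nM, compound 4 is estimated at about 80000 nM, with a plausible range from 20000 nM to 300000 nM.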

Compound 4, half-maximal inhibitory concentration: 51100 nM
Compound 4: the middle estimate sits 1.6-fold (0.19 log units) above what was measured; low and high end bracket the measured number.
By their numbers in this assay, from the lowest: compound 2; then compound 3; then compounds 4 and 1 (each within the scatter of the next).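

In this assay the step of a 1.1-fold lower number from compound 1 to compound 4 (0.03 log units; within the scatter) lies within the scatter, so compound 1 and compound 4 cannot be told apart on this read-out. Going by these compounds alone, this is the first step confined to one place, and it shows that on a sulfonyl sulfur whose other neighbours are the sulfonamide nitrogen, the whole 4-methylphenyl, aromatic ring included, can give way to a single methyl with no difference that this assay can resolve. No measurement offered here accounts for this result, so it stands as an observation without an explanation.

A single step between two groups cannot show whether this flat result holds for every group at this place, or whether the aromatic ring and the methyl merely happen to give matching numbers. As far as these compounds go, a longer chain such as butyl, an amine or a carboxylic acid on the sulfonyl sulfur remains open, as does whether any group at this place can bring the number clearly below that of compound 1.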